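From hydroxymethyl to cyclopentyl on compound 1

This account rests on a few compounds, and the source may have more. Where it says the series, first, only, none or still open, it means among the compounds named here.

Of the compounds shown here, three have been tested in an ADME assay on a cell-free system (plasma, Homo sapiens) for metabolic stability, read by LC-MS; on this read-out lower numbers stand for a shorter-lived compound and higher numbers for a longer-lived compound. Compound 1 (`NCc1ccc(C(=O)Nc2ccncc2F)cc1-c1cccc(C(=O)OCCO)c1`) gives 1.35 h. Compound 3 (`CCOC(=O)c1cccc(-c2cc(C(=O)Nc3ccncc3)ccc2CN)c1`) gives 0.683 h, which lies within the usual scatter of the number for compound 1. Compound 2 (`CC(N)c1ccc(C(=O)Nc2ccncc2)cc1-c1ccc(F)cc1`) reads > 2 h, and this is a limit, not a number.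

Compound 4 (`NCc1ccc(C(=O)Nc2ccncc2F)cc1-c1cccc(C(=O)OCC2CCCC2)c1`) has not been measured yet. It differs from compound 1 in one place: cyclopentyl in place of hydroxymethyl on a saturated chain carbon bound to an oxygen next to a carbonyl group. Cyclopentyl stands in place of hydroxymethyl on a saturated chain carbon bound to an oxygen next to a carbonyl group, so 2-hydroxyethyl becomes cyclopentylmethyl.

Among the compounds with values here, no measured pair shows this change, so any forecast rests on little. The two numbers available, compound 3 at 0.683 h and compound 1 at 1.35 h, stay within the scatter, which supports only a modest expectation. In this assay the expected step is small and slightly downward, a 1.4-fold lower number from compound 1 to compound 4 (0.13 log units; within the scatter), and not beyond the scatter. For compound 4 the estimated half-life is 1 h, with an expected range from 0.4 h to 2 h.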

Compound 4, half-life: 0.283 h
Estimate against measurement, compound 4: 3.5-fold (0.55 log units) above; the whole stated range lies above it.
By their numbers in this assay, from the lowest: compound 4; then compounds 3 and 1 (each within the scatter of the next). At a limit, above all of these: compound 2.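

This position is not a silent one: in this assay, replacing 2-hydroxyethyl with cyclopentylmethyl gives a 4.8-fold lower number from compound 1 to compound 4 (0.68 log units; beyond the scatter), while the rest of the molecule stays the same. Within the data shown here, this is the first comparison here in which two compounds differ in only one place, so it shows that the group at this saturated chain carbon can, on its own, move the half-life by more than repeat measurements would. It is still one pair, which gives the size and direction of this particular change but no general rule for the position.

As far as these compounds go, it remains open where a longer chain ending in hydroxyl, or a carboxylic acid, would fall relative to compound 1 and compound 4. Nothing among the measurements shown explains why the half-life moved with this change.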